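The source may report more compounds than this note shows. Statements on the series, on what has been measured and on what is new or still open speak of the compounds shown alone.

Values in a functional assay on BT-483 cells (Homo sapiens) for cytotoxicity, read by MTT assay, with a stated time of 24 h; on this read-out higher numbers stand for weaker inhibition and lower numbers for stronger inhibition:
- Compound 1 `CCNc1cc(-c2ccc(NC(=O)Nc3ccc(C)cc3)cc2C)ccn1`: 22000 nM
- Compound 2 `CCNc1cc(-c2ccc(NC(=O)Nc3c(C)cccc3C)cc2C)ccn1`: > 30000 nM, a limit and not a number
- Compound 3 `CCNc1cc(-c2ccc(NC(=O)Nc3ccc(C)cc3)cc2C(F)(F)F)ccn1`: 27100 nM

Compound 3, at 27100 nM, cannot be told apart from compound 1 on these numbers. Also in view is the limit of > 30000 nM in this assay, at which 1 of the 3 values shown sits.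

Compound 4 `CCNc1cc(-c2ccc(NC(=O)Nc3ccc(OC)cc3)cc2C(F)(F)F)ccn1` differs from compound 3 by methoxy in place of methyl on an aromatic carbon, para to a large group: methoxy in place of methyl on an aromatic carbon.

Among the measured compounds shown here, two measured steps bear on this change. Replacing the 4-methylphenyl group with 2,6-dimethylphenyl gave an at least 1.3-fold higher number from compound 1 to compound 2 (0.13 log units; that floor lies within the scatter). Trifluoromethyl in place of methyl gave a 1.2-fold higher number from compound 1 to compound 3 (0.09 log units; within the scatter). Neither step tests methoxy directly. With only these small steps as a guide, no shift beyond the scatter is expected in this assay, and no direction can be favoured with confidence. The expected change is a 1.2-fold lower number from compound 3 to compound 4 (0.07 log units; within the scatter).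

For compound 4 the estimate is 23000 nM, with an expected range from 11000 nM to 33000 nM.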

Compound 4, half-maximal inhibitory concentration: 17600 nM
Beside the measured number, compound 4's estimate is 1.3-fold (0.12 log units) above it, and the stated range covers the measured number.
By their numbers in this assay, from the lowest: compounds 4, 1 and 3 (each within the scatter of the next). At a limit, above all of these: compound 2.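

In this assay, methoxy in place of methyl on an aromatic carbon, para to a large group, gave a 1.5-fold lower number from compound 3 to compound 4 (0.19 log units; within the scatter). Among the compounds shown here, this is the first direct test of this change: the position accepts 4-methoxyphenyl in place of 4-methylphenyl, with one added hydrogen-bond acceptor by count, without a shift that can be told from the scatter. Compound 2 remains a limit and not a number: the limit of > 30000 nM in this assay, at which 1 of the 4 values shown sits.

As far as these compounds go, it remains open whether an amine, a carboxylic acid or a longer chain such as ethoxy at this position would move the number beyond the scatter. Also open, from the compounds shown here alone, is whether methoxy reads the same on the core of compound 1, which carries methyl where compound 3 carries trifluoromethyl.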